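This account rests on a few compounds, and the source may have more. Where it says the series, first, only, none or still open, it means among the compounds named here.

Measured in a functional assay on A549 cells (Homo sapiens) for cytotoxicity, read by MTT assay, with a stated time of 48 h; on this read-out lower numbers stand for stronger inhibition and higher numbers for weaker inhibition:
- compound 1 `O=c1cc(-c2ccccc2)oc2c(OCCCCNC3CCCCC3)c(O)cc(O)c12`: "not determined" (no result reported)
- compound 2 `CCCCNCCCCOc1c(O)cc(O)c2c(=O)cc(-c3ccccc3)oc12`: "not determined" (no result reported)
- compound 3 `CCN(CC)CCCOc1c(O)cc(O)c2c(=O)cc(-c3ccccc3)oc12`: > 100000 nM

Within the data shown here, three compounds sharing one core were taken into this assay, but only one returned a reading. Compound 3 gave > 100000 nM, which is a limit of the assay and not a number. This places compound 3 at the limit of > 100000 nM in this assay, at which 1 of the 3 values shown sits. Among the measured compounds shown here, compound 1 and compound 2 have no reported result, so no step between measured compounds is available as a guide.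

The next compound to be measured is compound 4 `CN1CCN(CCCCOc2c(O)cc(O)c3c(=O)cc(-c4ccccc4)oc23)CC1`. Its difference from compound 3 is (4-methylpiperazin-1-yl)methyl in place of diethylamino on a saturated chain carbon, three bonds along the chain from an oxygen on an aromatic ring. In words, (4-methylpiperazin-1-yl)methyl stands in place of diethylamino on a saturated chain carbon, three bonds along the chain from an oxygen on an aromatic ring.

The only anchor for the expectation is compound 3 at > 100000 nM, again a limit. A small move toward stronger inhibition is expected, with an estimated at least 1.6-fold lower number from compound 3 to compound 4 (0.22 log units; that floor lies within the scatter), and this may not clear the usual scatter. It is also quite possible that the assay will again report only a limit. If a number is obtained, the estimate for compound 4 is 60000 nM, with an expected range of 20000 nM to 120000 nM.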

Compound 4, half-maximal inhibitory concentration: > 100000 nM
Compound 4: a limit, no number (the forecaster's own chance of this, stated with the estimate: 55%); middle value at least 1.6-fold (0.22 log units) away from the limit.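

Among these compounds, compound 3 and compound 4 both stand at a limit of the assay and not at a number, so no step between them can be read: the limit of > 100000 nM in this assay, at which 2 of the 4 values shown sit.

The compounds shown leave open whether (4-methylpiperazin-1-yl)methyl in place of diethylamino changes the result in this assay at all, and whether any compound of this set gives a number there.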